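Swapping the ethyl for a bromophenyl on the ring nitrogen

The source may report more compounds than this note shows. Statements on the series, on what has been measured and on what is new or still open speak of the compounds shown alone.

Of the compounds shown here, three of a shared core have been measured in a functional assay on aorta with Alpha-1D adrenergic receptor (Rattus norvegicus) as the target; on this read-out higher numbers stand for an effect only at larger amounts of compound and lower numbers for an effect already at smaller amounts. Compound 3 `CCn1nc(Cc2ccc(Cl)cc2)c2ccccc2c1=O` gives 1300 nM, the lowest of the two numbers obtained; its nearest neighbour is compound 2 `O=c1c2ccccc2c(Cc2ccc(Cl)cc2)nn1-c1ccc([N+](=O)[O-])cc1`, which gives 29000 nM. Compound 1 `CC(C)(C)n1nc(Cc2ccc(Cl)cc2)c2ccccc2c1=O` gives > 100000 nM, which is a limit of this assay and not a number. The steps are clear: an at least 76-fold lower number from compound 1 to compound 3 (1.88 log units; beyond the scatter), a 22-fold lower number from compound 2 to compound 3 (1.35 log units; beyond the scatter) and an at least 3.4-fold lower number from compound 1 to compound 2 (0.53 log units; beyond the scatter).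

Compound 4 `O=c1c2ccccc2c(Cc2ccc(Cl)cc2)nn1-c1ccc(Br)cc1` has not yet been measured. It differs from compound 3 in one place: 4-bromophenyl in place of ethyl on an aromatic nitrogen. The step that bears most directly on it is the reverse of the one from the nitrophenyl to the ethyl, since a 22-fold lower number from compound 2 to compound 3 (1.35 log units; beyond the scatter) shows that replacing a 4-substituted phenyl on that nitrogen with ethyl lowered the number by a large margin. Going back from ethyl to a 4-bromophenyl is therefore expected to raise the number in this assay by a large step, a 12-fold higher number from compound 3 to compound 4 (1.06 log units; beyond the scatter), landing compound 4 near where compound 2 stands, though the bromine is not the nitro group and some deviation is expected. Compound 4 is estimated at 15000 nM, with a plausible range from 4000 nM to 60000 nM.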

Compound 4, half-maximal effective concentration: > 30000 nM
Compound 4 ended at the assay's limit; the forecaster's own chance of this, stated with the estimate: 10%; middle value at least 2.0-fold (0.30 log units) from the limit.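

In this assay compound 4 gives > 30000 nM, which is a limit of the assay and not a number. Even so, it places a second 4-substituted phenyl on the ring nitrogen far from ethyl, an at least 23-fold higher number from compound 3 to compound 4 (1.36 log units; beyond the scatter), so that among the four compounds shown ethyl now stands apart from tert-butyl, 4-nitrophenyl and 4-bromophenyl alike. Bromo in place of nitro gives an at least 1.0-fold higher number from compound 2 to compound 4 (0.01 log units; that floor lies within the scatter), a floor that puts the two phenyl compounds in no order, and the step between the limits of compound 1 and compound 4 cannot be read.

From the compounds shown here alone, it remains open whether the lower number belongs to ethyl alone or extends to other chains on that nitrogen, such as methyl, a longer propyl chain or an ethyl chain ending in an amine. How far compound 4 lies past its limit is also unknown, which leaves open whether any group at the 4-position of the phenyl, such as a carboxylic acid or a methoxy group, could bring the number down toward that of compound 3.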